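Swapping the pyridine for a methylphenyl on the oxadiazole

The source may report more compounds than this note shows. Statements on the series, on what has been measured and on what is new or still open speak of the compounds shown alone.

Of the compounds shown here, three sharing one core have been tested in a functional assay on HCT-116 cells (Homo sapiens) for inhibition, read by MTT assay, with a stated time of 24 h, tested at 5 uM; a higher number here means more inhibition of growth at the concentration tested, a lower number less inhibition of growth. Compound 1 `O=c1c(-c2nnc(-c3ccc(F)cc3)o2)c[nH]c2ncc(-c3cccnc3)cc12` gives 11.1%, compound 2 `CS(=O)(=O)c1ccc(-c2cnc3[nH]cc(-c4nnc(-c5ccccn5)o4)c(=O)c3c2)cc1` gives 11.3%, and compound 3 `O=c1c(-c2nnc(-c3ccc(Cl)cc3)o2)c[nH]c2ncc(-c3cccnc3)cc12` gives 15.9%; all three numbers sit within the usual scatter of one another, so no order among them can be read. Going by the values given here, the only step measured so far, a number 4.8 percentage points higher from compound 1 to compound 3 (within the scatter), concerns a different part of the molecule. Compound 4 `Cc1cccc(-c2nnc(-c3c[nH]c4ncc(-c5ccc(S(C)(=O)=O)cc5)cc4c3=O)o2)c1` differs from compound 2 by 3-methylphenyl in place of pyridin-2-yl on an aromatic carbon. Among the compounds with values here, no measured step touches this position, so there is nothing to suggest movement beyond the scatter. Compound 4 is therefore expected to give about 12%, between 2% and 24%, a step of a number 0.7 percentage points higher from compound 2 to compound 4 (within the scatter) that is estimated to stay within the scatter.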

Compound 4, percent growth inhibition at one concentration: 20.4%
Compound 4: the middle estimate sits 8.4 percentage points below what was measured; low and high end bracket the measured number.
By their numbers in this assay, from the lowest: compounds 1, 2, 3 and 4 (each within the scatter of the next).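

In this assay, 3-methylphenyl in place of pyridin-2-yl gives a number 9.1 percentage points higher from compound 2 to compound 4 (within the scatter). Going by these compounds alone, this is the first measured step at this position, and it shows that a carbon-only aromatic ring with a methyl group can take the place of the pyridine ring without a change beyond the scatter. Nothing available bears on what lies behind this number. On these data alone, it remains open whether an amine, a carboxylic acid or a longer chain at this position would give a step beyond the scatter.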